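Swapping the pyridyl substituent on the thiazole acetic acid core

The compounds below may be only part of what the source reports. "The series", "measured", "known", "first", "only" and "open" are said of these compounds alone.

Measured compounds:
compound 1 `N#Cc1cc(-c2nc(C(c3ccc(F)cc3)c3ccc(F)cc3)sc2CC(=O)O)ccc1F`: 57 nM
compound 2 `CS(=O)(=O)Nc1cccc(-c2nc(C(c3ccc(F)cc3)c3ccc(F)cc3)sc2CC(=O)O)c1`: 40 nM
compound 3 `O=C(O)Cc1sc(C(c2ccc(F)cc2)c2ccc(F)cc2)nc1-c1ccnc(Cl)c1`: 3.1 nM

Of the compounds shown here, three sharing one core have been measured in an in vitro assay on HEK385-7 cells for displacement of a labelled ligand from prostaglandin D2 receptor 2 (Homo sapiens); on this read-out higher numbers stand for weaker inhibition and lower numbers for stronger inhibition. Compound 1 gives 57 nM and compound 2 gives 40 nM; their step, a 1.4-fold lower number from compound 1 to compound 2 (0.15 log units; within the scatter), shows no difference beyond the scatter. Compound 3 stands apart: in this assay compound 3 gives 3.1 nM, the lowest of the three numbers, with an 18-fold lower number from compound 1 to compound 3 (1.26 log units; beyond the scatter) and a 13-fold lower number from compound 2 to compound 3 (1.11 log units; beyond the scatter) both large and beyond the scatter.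

Compound 4 `Nc1cc(-c2nc(C(c3ccc(F)cc3)c3ccc(F)cc3)sc2CC(=O)O)cc(F)n1` has not yet been measured. It differs from compound 3 in one place: 2-amino-6-fluoropyridin-4-yl in place of 2-chloropyridin-4-yl on an aromatic carbon. For the measured compounds named here, the two measured steps that bear on this position, an 18-fold lower number from compound 1 to compound 3 (1.26 log units; beyond the scatter) and a 13-fold lower number from compound 2 to compound 3 (1.11 log units; beyond the scatter), show that changing the aryl group here can move the number by a large amount, but no measured pair tests an amino or a fluorine substituent on the pyridine itself. Because compound 3 gives 3.1 nM and the pyridine ring is kept, compound 4 is expected to stay in the same potent range, with a step of a 1.6-fold higher number from compound 3 to compound 4 (0.21 log units; within the scatter) expected, small or within the scatter. The estimate for compound 4 in this assay is 5 nM, in a range from 1.5 nM to 20 nM.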

Compound 4, half-maximal inhibitory concentration: 220 nM
Compound 4: the middle estimate sits 44-fold (1.64 log units) below what was measured; measured number above the stated range.
By their numbers in this assay, from the lowest: compound 3; then compounds 2 and 1 (each within the scatter of the next); then compound 4.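

Keeping the pyridine ring did not keep the number in this assay: the step of a 71-fold higher number from compound 3 to compound 4 (1.85 log units; beyond the scatter) is the largest seen at this position, and it comes from a change of substituents on the pyridine alone. The 2-amino-6-fluoropyridin-4-yl group also gives a higher number than either group carried by the earlier, weaker compounds, with a 5.5-fold higher number from compound 2 to compound 4 (0.74 log units; beyond the scatter) and a 3.9-fold higher number from compound 1 to compound 4 (0.59 log units; beyond the scatter) both beyond the scatter, so having a pyridine here does not by itself give the low number of compound 3. Nothing measured among these compounds accounts for the size of this step.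

The amino group and the fluorine enter together as the chlorine leaves, so the compounds shown do not separate the share of each. The simpler 2-aminopyridin-4-yl and 2-fluoropyridin-4-yl groups would divide that step, and a 2-methoxypyridin-4-yl or 2-methylpyridin-4-yl group would show whether anything other than chlorine holds the number near that of compound 3.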